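Removing a ring methyl and clearance in rat liver microsomes

The source may hold more compounds than are shown below. What is called first, only, known or untested is meant among the compounds shown, and "the series" means these compounds.

Compound 1 `C[C@]1(O)C[C@@](c2cccc(C(F)(F)F)c2)([C@H](O)c2ccccn2)C1` was measured in an ADME assay on liver for metabolic stability, with Liver microsome (Rattus norvegicus) as the target, read by LC-MS, using microsomes, with a stated time of 5 h (a lower number here means slower removal, a higher number faster removal of the compound), where compound 1 gives 317 mL/min/kg. Compound 2 `C[C@]1(O)C[C@@](c2cc(C(F)(F)F)ccn2)([C@H](O)c2ccccn2)C1` gives 117 mL/min/kg in this assay, and compound 3 `O[C@H](c1ccccn1)[C@]1(c2cc(C(F)(F)F)ccn2)C[C@@H](O)C1` gives 50 mL/min/kg. The difference between the cores of compound 1 and compound 2 is not broken down here. From compound 2 to compound 3 the change is hydrogen in place of methyl on a saturated ring carbon, and it gave a 2.3-fold lower number from compound 2 to compound 3 (0.37 log units; beyond the scatter). Compound 4 `O[C@H](c1ccccn1)[C@]1(c2cccc(C(F)(F)F)c2)C[C@@H](O)C1` has not yet been measured; it differs from compound 1 by hydrogen in place of methyl on a saturated ring carbon, the same change made on the core of compound 1. The step expected in this assay is a 2.3-fold lower number from compound 1 to compound 4 (0.36 log units; beyond the scatter), resting on the measured 2.3-fold lower number from compound 2 to compound 3 (0.37 log units; beyond the scatter). Compound 4 is therefore estimated to give 138 mL/min/kg, expected to fall between 70 mL/min/kg and 280 mL/min/kg.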

Compound 4, clearance: 100 mL/min/kg
Beside the measured number, compound 4's estimate is 1.4-fold (0.14 log units) above it; measured number inside the range.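

Putting hydrogen in place of the methyl on the core of compound 1 gave a 3.2-fold lower number from compound 1 to compound 4 (0.50 log units; beyond the scatter) in this assay. The change lowers the number on both cores, and the two steps agree in size: the same change on two cores in this assay, a 2.3-fold lower number (0.37 log units; beyond the scatter) from compound 2 to compound 3 and a 3.2-fold lower number (0.50 log units; beyond the scatter) from compound 1 to compound 4, 1.4-fold (0.13 log units) apart, within the scatter of two such steps

Among the compounds shown here, this shows that the step carried over between these two closely related cores, but with only two pairs of compounds it does not show that it would carry to any other core, nor does it explain why clearance falls. The compounds shown leave open what other groups on this saturated ring carbon would do, such as an ethyl group, a fluorine atom or an amine in place of the methyl.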